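Swapping iodo for azido on a fluoro-bearing compound

A few compounds are considered here, and "the series" means these few. Any claim that something is new, unique, unknown or untested is made for them only; others in the source may bear on it.

In a functional assay on cells (Homo sapiens) for antiproliferative activity, read by WST assay, with a stated time of 3 days (a lower number here means a stronger inhibitor, a higher number a weaker inhibitor), compound 1 `O=c1cc(I)n([C@@H]2O[C@H](CO)[C@@H](O)[C@H]2O)c(=O)[nH]1` gives 27800 nM, a measured number. Compound 2 `[N-]=[N+]=Nc1cc(=O)[nH]c(=O)n1[C@@H]1O[C@H](CO)[C@@H](O)[C@H]1O` gives > 50000 nM, which is a limit of the assay and not a number. Compound 3 `O=c1[nH]c(=O)n([C@@H]2O[C@H](CO)[C@@H](O)[C@H]2O)c(I)c1F` gives > 50000 nM, which is also a limit. On these data alone, compound 3 therefore stands at the limit of > 50000 nM in this assay, at which 2 of the 3 values shown sit, and its true value is unknown.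

Compound 4 `[N-]=[N+]=Nc1c(F)c(=O)[nH]c(=O)n1[C@@H]1O[C@H](CO)[C@@H](O)[C@H]1O` has not been measured yet. It differs from compound 3 by a single change: azido in place of iodo on an aromatic carbon.

Among the compounds with values here, two measured steps bear on this change. The same exchange of azido for iodo, made without the fluoro group, is an at least 1.7-fold higher number from compound 1 to compound 2 (0.25 log units; that floor lies within the scatter). Adding the fluoro group in place of hydrogen is an at least 1.7-fold higher number from compound 1 to compound 3 (0.25 log units; that floor lies within the scatter). Both steps end at a limit, so they give only floors, and neither shows the full size of its change.

Compound 2 has the azido group and compound 3 has the fluoro group, and each of them ends at the limit. Compound 4 carries both groups, so it is expected to remain in that same region, with no step beyond the scatter. In this assay the expected step is a number no higher from compound 3 to compound 4 (the limit leaves the size open). For compound 4 the estimated value is 50000 nM, with an expected range from 20000 nM to 100000 nM.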

Compound 4, half-maximal inhibitory concentration: 600 nM
The estimate for compound 4 lay 83-fold (1.92 log units) above the measured number; the measured number lies below the stated range.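

In this assay, azido in place of iodo on the aromatic carbon ortho to a fluoro group gives an at least 83-fold lower number from compound 3 to compound 4 (1.92 log units; beyond the scatter), so this position can carry a large change in the number once the fluoro group is present. What the azido group does here depends on the neighbouring group, as the same exchange made with and without the fluoro group gives clearly different steps: the same change on two cores in this assay, an at least 1.7-fold higher number (0.25 log units; that floor lies within the scatter) from compound 1 to compound 2 and an at least 83-fold lower number (1.92 log units; beyond the scatter) from compound 3 to compound 4, at least 140-fold (2.17 log units) apart, beyond the scatter of two such steps The fluoro group shows the same dependence, giving an at least 83-fold lower number from compound 2 to compound 4 (1.92 log units; beyond the scatter) when azido already sits on the ring, which the iodo compounds gave no sign of: the same change on two cores in this assay, an at least 1.7-fold higher number (0.25 log units; that floor lies within the scatter) from compound 1 to compound 3 and an at least 83-fold lower number (1.92 log units; beyond the scatter) from compound 2 to compound 4, at least 140-fold (2.17 log units) apart, beyond the scatter of two such steps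

The compounds shown cannot tell whether this strong result needs azido itself, or whether an amine or a nitrile on the same carbon, or a chloro group in place of the fluoro group, would give a similar number. Both steps are also only floors, so their full size remains unknown, and nothing here explains why the two groups work only in combination.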